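The compounds below may be only part of what the source reports. "The series", "measured", "known", "first", "only" and "open" are said of these compounds alone.

The measured compounds are compound 1, `COc1cc(-c2cc(/C=C/C(=O)c3ccc(N)cc3)[nH]n2)cc(OC)c1OC`, with 1780 nM; compound 2, `COc1ccc(-c2cc(/C=C/C(=O)c3ccc(N)cc3)[nH]n2)cc1OC`, with 2620 nM; and compound 3, `COc1cc(C(=O)/C=C/c2cc(-c3cc(OC)c(OC)c(OC)c3)n[nH]2)cc(OC)c1OC`, with 1640 nM. All three values come from a functional assay on OVCAR-5 cells (Homo sapiens) for inhibition, read by sulforhodamine B assay, with a stated time of 48 h; on this read-out higher numbers stand for weaker inhibition of growth and lower numbers for stronger inhibition of growth.

Compound 1 and compound 2 share a core and differ in one place: hydrogen in place of methoxy on an aromatic carbon. This change gave a 1.5-fold higher number from compound 1 to compound 2 (0.17 log units; within the scatter). Compound 3 is built on a different core; the difference between the core of compound 3 and the core of compound 1 is not broken down here. The values of compound 3, compound 1 and compound 2 all lie within the scatter of one another, so no order is drawn among them.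

Compound 4, `COc1ccc(-c2cc(/C=C/C(=O)c3cc(OC)c(OC)c(OC)c3)[nH]n2)cc1OC`, has not yet been measured in this assay. It differs from compound 3 by hydrogen in place of methoxy on an aromatic carbon, the same change, at the same place, as that from compound 1 to compound 2. Within the data shown here, the only guide to what this change does is a 1.5-fold higher number from compound 1 to compound 2 (0.17 log units; within the scatter). The estimate for compound 4 therefore rests on compound 3 with 1640 nM and on that earlier step. The step that this estimate means is expected to be a 1.5-fold higher number from compound 3 to compound 4 (0.17 log units; within the scatter). For compound 4 in this assay the expected value is 2400 nM, with a range from 1200 nM to 5000 nM.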

Compound 4, concentration for 50% growth inhibition: 1760 nM
The estimate for compound 4 lay 1.4-fold (0.13 log units) above the measured number, within the range that was stated.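

In this assay, putting hydrogen in place of methoxy on the core of compound 3 gave a 1.1-fold higher number from compound 3 to compound 4 (0.03 log units; within the scatter), so on this second core, too, the change produced no step beyond the scatter. Set beside the earlier step, the new one does not differ from it: the same change on two cores in this assay, a 1.5-fold higher number (0.17 log units; within the scatter) from compound 1 to compound 2 and a 1.1-fold higher number (0.03 log units; within the scatter) from compound 3 to compound 4, 1.4-fold (0.14 log units) apart, within the scatter of two such steps. This shows that, across these two pairs, the change carried from one core to the other without a step that could be told from the scatter, but it does not show that the two cores respond identically, that the methoxy group is without effect on growth inhibition elsewhere in the series, or that a third core would behave the same way.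

The compounds shown have only methoxy or hydrogen at this place on the ring, so it remains open what a hydroxyl group, a fluorine or chlorine atom, or a longer chain such as ethoxy would do there. As far as these compounds go, it also remains open whether removing the methoxy groups at the other places on the ring, alone or together, would give a step beyond the scatter on either core.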